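From Methoxycarbonyl to Ethoxycarbonyl in a Growth Assay

The source may hold more compounds than are shown below. What is called first, only, known or untested is meant among the compounds shown, and "the series" means these compounds.

Among the compounds with values here, in a functional assay on HT-29 cells (Homo sapiens) for antiproliferative activity, read by MTT assay, with a stated time of 48 h (on this read-out lower numbers stand for stronger inhibition of growth and higher numbers for weaker inhibition of growth), two compounds have numbers so far. Compound 2 (`COC(=O)N1N=C(c2cccc(O)c2)CC1c1cc(OC)c(OC)c(OC)c1`) gives 1350 nM as the lower of the two. Compound 1 (`CCOC(=O)N1N=C(c2ccccc2)CC1c1cc(OC)c(OC)c(OC)c1`) gives 8920 nM as the higher number, and that gap lies beyond the scatter.

Compound 3 (`CCOC(=O)N1N=C(c2cccc(O)c2)CC1c1cc(OC)c(OC)c(OC)c1`) has not yet been measured. It carries methyl in place of hydrogen on a saturated chain carbon bound to an oxygen next to a carbonyl group and so turns methoxycarbonyl into ethoxycarbonyl. Within the data shown here, no measured pair shows this change alone, so the expectation in this assay is a small upward step and none beyond the scatter. The starting point for this expectation is compound 2 at 1350 nM as the anchor. The estimated step runs a 1.3-fold higher number from compound 2 to compound 3 (0.12 log units; within the scatter) on this reasoning. Compound 3 is expected to give about 1800 nM within an estimated range from 700 nM to 4500 nM in this test.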

Compound 3, concentration for 50% growth inhibition: 11600 nM
Beside the measured number, compound 3's estimate is 6.4-fold (0.81 log units) below it; the measured number lies above the stated range.
By their numbers in this assay, from the lowest: compound 2; then compounds 1 and 3 (each within the scatter of the next).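

In this assay, within the data shown here, turning methoxycarbonyl into ethoxycarbonyl is the first change that can be read on its own, and it gives an 8.6-fold higher number from compound 2 to compound 3 (0.93 log units; beyond the scatter), which here means weaker inhibition of growth. So a single added methyl on a saturated chain carbon bound to an oxygen next to a carbonyl group is enough to move this number beyond the scatter, while with ethoxycarbonyl in place, hydroxy in place of hydrogen on an aromatic carbon gives only a 1.3-fold higher number from compound 1 to compound 3 (0.11 log units; within the scatter). Nothing measured here offers a reason for the effect of the methyl group.

Going by these compounds, what a longer chain such as propoxycarbonyl, or an amide in place of the ester, would do at this position remains open. These compounds also cannot show whether the hydroxy group counts for more when methoxycarbonyl is present.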